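This account rests on a few compounds, and the source may have more. Where it says the series, first, only, none or still open, it means among the compounds named here.

Compound 1 `CCn1c(SCC(=O)Nc2ccc(/C(C)=N/O)cc2)nnc1-c1ccc(OC)c(OC)c1` gives 53% in a functional assay on the whole organism (strain albino) for inhibition, with Rattus norvegicus as the target, read by paw edema, with stated times of 30 min and 1 h, at a dose of 0.28 mmol/kg by the oral route; a higher number here means more inhibition at the dose given (going by the name of the read-out), a lower number less inhibition. Compound 2 `COc1ccc(-c2nnc(SCC(=O)Nc3ccc(/C(C)=N/O)cc3)n2-c2ccccc2)cc1OC` gives 57%. Compound 3 `C=CCn1c(SCC(=O)Nc2ccc(C(C)=O)cc2)nnc1-c1ccc(OC)c(OC)c1` gives 56%.

Among these three numbers compound 3 stands second highest, and all three lie within the usual scatter of one another, so none of the numbers can be called higher or lower than the others. Among the measured compounds shown here, the only measured step that isolates a single change, a number 4 percentage points higher from compound 1 to compound 2 (within the scatter), concerns the group on the aromatic nitrogen and does not bear on the change now considered. Compound 4 `C=CCn1c(SCC(=O)Nc2ccc(/C(C)=N/O)cc2)nnc1-c1ccc(OC)c(OC)c1` differs from compound 3 in one place: a group of 4 heavy atoms (2 carbon, 1 nitrogen, 1 oxygen; no ring) in place of a group of 3 heavy atoms (2 carbon, 1 oxygen; no ring), on an aromatic carbon. For the measured compounds named here, the same group that enters here is already present in compound 1 and compound 2, whose values sit close to that of compound 3, but no measured pair separates this change from the change on the aromatic nitrogen. On that basis no step beyond the scatter is expected, and the estimated step is a number 1 percentage points lower from compound 3 to compound 4 (within the scatter). Compound 4 is therefore expected to give about 55%, estimated to fall between 44% and 66%.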

Compound 4, a percentage reported as inhibition, in the whole organism at one dose (the size of the read-out at that dose, not a potency): 53%
For compound 4 the middle estimate is 2 percentage points above the measured one; the range from low to high includes it.
By their numbers in this assay, from the lowest: compounds 1, 4, 3 and 2 (each within the scatter of the next).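

In this assay the exchange of acetyl for the group of 4 heavy atoms, on the aromatic carbon para to a large group, can now be read on its own: the step is a number 3 percentage points lower from compound 3 to compound 4 (within the scatter) and so cannot be told from noise at this dose. With that group held in place, allyl in place of phenyl on the aromatic nitrogen gives a number 4 percentage points lower from compound 2 to compound 4 (within the scatter) and vinyl in place of methyl on the chain carbon bound to that nitrogen gives no change at the digits printed from compound 1 to compound 4 (within the scatter), so neither change separates these compounds. No measurement offers an explanation for these results.

As far as these compounds go, whether an amine or a carboxylic acid at the place of acetyl would shift the number beyond the scatter remains open. So does the effect of a longer chain such as butyl on the aromatic nitrogen.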